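The source may hold more compounds than are shown below. What is called first, only, known or untested is meant among the compounds shown, and "the series" means these compounds.

Measured so far:
compound 1 `CN(C)c1ccc(CNC(=O)c2nc(Br)c3cccnc3c2N[C@H]2CC[C@H](N)CC2)cc1` — a functional assay on SK-BR-3 cells (Homo sapiens) for cytotoxicity, read by MTT assay, with a stated time of 72 h; a lower number here means a stronger inhibitor, a higher number a weaker inhibitor: "not determined" (no result reported)
compound 2 `O=C(NCCCNc1c(C(=O)NCc2ccc(F)cc2)nc(Br)c2cccnc12)c1ccccc1` — this assay: 1000 nM

Compound 1 has no number in this assay, so its standing in the series cannot be placed; it is a structural reference point only. Compound 2 is the single measured anchor of the shared core, and in this assay compound 2 gives 1000 nM.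

Compound 3 `N[C@H]1CC[C@H](Nc2c(C(=O)Nc3ccccc3)nc(Br)c3cccnc23)CC1` differs from compound 1 in one place: phenyl in place of 4-(dimethylamino)benzyl on an amide-type nitrogen.

Among the compounds with values here, no pair of measured compounds shows this change, so nothing reads its size in this assay directly. The expectation is a modest step at most, of a size within the usual scatter, with no clear direction.

Within the data shown here, compound 3 is expected near 2000 nM, in a range of 400 nM to 10000 nM, taking compound 2 with 1000 nM as the only measured guide for this core.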

Compound 3, half-maximal inhibitory concentration: 2000 nM
Estimate against measurement, compound 3: no gap at the digits printed; the range from low to high includes it.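

With compound 1 at "not determined" (no result reported) and compound 3 at 2000 nM in this assay no step can be read between them. No measured evidence bears on the result for compound 3. The compounds shown leave open what phenyl in place of 4-(dimethylamino)benzyl does on the shared core.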